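Swapping the aryl group on a triazole-linked lactone

This account rests on a few compounds, and the source may have more. Where it says the series, first, only, none or still open, it means among the compounds named here.

Compound 1 `O=C1O/C(=C\Cn2cc(-c3cc(F)cc(F)c3)nn2)C(OCc2ccccc2)=C1OCc1ccccc1` gives > 100000 nM in a functional assay on HepG2 cells (Homo sapiens) for antiproliferative activity, read by MTT assay, with a stated time of 72 h; on this read-out higher numbers stand for weaker inhibition and lower numbers for stronger inhibition.
Compound 2 `O=C1O[C@H]([C@@H](O)Cn2cc(-c3cccc(O)c3)nn2)C(OCc2ccccc2)=C1OCc1ccccc1` gives 62700 nM in this assay.
Compound 3 `COc1ccc(-c2cn(C[C@H](O)[C@H]3OC(=O)C(OCc4ccccc4)=C3OCc3ccccc3)nn2)cc1` gives 46400 nM in this assay.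

The value of compound 1 is a limit of the assay and not a number: it stands at the limit of > 100000 nM in this assay, at which 1 of the 3 values shown sits. Compound 4 `O=C1O/C(=C\Cn2cc(-c3ccc(Br)cc3)nn2)C(OCc2ccccc2)=C1OCc1ccccc1` differs from compound 1 by 4-bromophenyl in place of 3,5-difluorophenyl on an aromatic carbon. Within the data shown here, only one measured step exchanges the group on the same five-membered ring, namely a 1.4-fold lower number from compound 2 to compound 3 (0.13 log units; within the scatter). That step was seen in compounds 2 and 3, whose shared core differs from that of compound 1 elsewhere in the molecule, so it bears on the present change only loosely, and it moved the number by less than the scatter. Among the measured compounds shown here, no measured step exchanges one halogen-bearing phenyl for another. The change from compound 1 to compound 4 is therefore expected to bring no step beyond the scatter in this assay, and since compound 1 stands at a limit, compound 4 may again be reported only as a limit. For compound 4 the estimate is 100000 nM, with a range from 40000 nM to 300000 nM. This means an expected step of a number no higher from compound 1 to compound 4 (the limit leaves the size open).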

Compound 4, half-maximal inhibitory concentration: > 100000 nM
Compound 4 gave a limit, no number; the forecaster's own chance of this, stated with the estimate: 65%; the middle value lies on the limit itself.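

In this assay compound 4 gives > 100000 nM, which is a limit of the assay and not a number. Among these compounds, compound 1 stands at a limit too, and no step between compound 1 and compound 4 can be read: the limit of > 100000 nM in this assay, at which 2 of the 4 values shown sit. As far as these compounds go, whether 4-bromophenyl or 3,5-difluorophenyl goes with stronger inhibition on the shared core remains open.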